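Benzyl ether variation on an isoflavone-type core

This account rests on a few compounds, and the source may have more. Where it says the series, first, only, none or still open, it means among the compounds named here.

Compound 1 `COc1cc(OC)c(-c2coc3cc(OCC=C(C)C)ccc3c2=O)cc1OC` gives 3500 nM in a functional assay on U-251 cells (Homo sapiens) for antiproliferative activity, read by MTT assay, with a stated time of 24 h; on this read-out higher numbers stand for weaker inhibition and lower numbers for stronger inhibition. Compound 2 `COc1cc(OC)c(-c2coc3cc(OCc4ccccc4C)ccc3c2=O)cc1OC` gives 2000 nM in this assay, and the gap a 1.8-fold lower number from compound 1 to compound 2 (0.24 log units; within the scatter) stays within the scatter, so compound 2 stands alongside compound 1 rather than apart from it. Compound 3 `COc1cc(OC)c(-c2coc3cc(OCc4cccc(C(F)(F)F)c4)ccc3c2=O)cc1OC` carries the change (3-(trifluoromethyl)phenyl in place of 2-methylphenyl on a saturated chain carbon bound to an oxygen on an aromatic ring). Within the data shown here, the only measured step touching this position, a 1.8-fold lower number from compound 1 to compound 2 (0.24 log units; within the scatter), is itself within the scatter, so no step beyond the scatter is expected, and the shift a 1.1-fold lower number from compound 2 to compound 3 (0.05 log units; within the scatter) is estimated as small. Compound 3 is therefore expected to give about 1800 nM in this assay, with a range of 800 nM to 4000 nM.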

Compound 3, half-maximal inhibitory concentration: > 10000 nM
Compound 3: a limit, no number; the forecaster's own chance of this, stated with the estimate: 5%; middle value at least 5.5-fold (0.74 log units) away from the limit.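

In this assay compound 3 reaches a limit of the assay and not a number: the limit of > 10000 nM in this assay, at which 1 of the 3 values shown sits.

This position is not indifferent to the group it carries, as the earlier pair could not show: the change to 3-(trifluoromethyl)phenyl gives an at least 5.0-fold higher number from compound 2 to compound 3 (0.69 log units; beyond the scatter), and an at least 2.8-fold higher number from compound 1 to compound 3 (0.45 log units; beyond the scatter). Both steps lie beyond the scatter, so the weaker inhibition holds against 2-methylphenyl and against 2-methylprop-1-en-1-yl.

Going by these compounds, what remains open is whether this follows from the trifluoromethyl group itself or from the removal of the methyl group. On these data alone, how a plain phenyl, or a phenyl carrying an amine or a carboxylic acid, would read here also remains open.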